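The compounds below may be only part of what the source reports. "The series", "measured", "known", "first", "only" and "open" are said of these compounds alone.

In a functional assay on MOLT-4 cells (Homo sapiens) for inhibition (a higher number here means a weaker inhibitor, a lower number a stronger inhibitor), three compounds have been measured. Compound 1 `Cc1cccc(/C=C2\Cc3ccccc3C2=O)c1` gives 80300 nM. Compound 2 `COc1cccc(/C=C2\Cc3ccccc3C2=O)c1` gives only a limit of the assay, > 500000 nM. Compound 3 `Cc1cccc(/C=C2\CCCCCC2=O)c1` gives 228000 nM.

Compound 1 and compound 2 share a core and differ by methoxy in place of methyl on an aromatic carbon. The result is an at least 6.2-fold higher number from compound 1 to compound 2 (0.79 log units; beyond the scatter), a step that runs into a limit, (the limit of > 500000 nM in this assay, at which 1 of the 3 values shown sits). Compound 3 carries another core, and the difference between the two cores is not broken down here; of the two plain numbers in this assay, compound 3 has the higher. Compound 4 `COc1cccc(/C=C2\CCCCCC2=O)c1`, not yet measured, stands to compound 3 as compound 2 stands to compound 1: methoxy in place of methyl on an aromatic carbon. This is the same kind of change, though the place is described as meta to a large group in one pair and as meta to a group of 9 heavy atoms in the other. Because the same change gave an at least 6.2-fold higher number from compound 1 to compound 2 (0.79 log units; beyond the scatter), a step of similar size is expected here: a 6.6-fold higher number from compound 3 to compound 4 (0.82 log units; beyond the scatter). Compound 4 is therefore estimated at 1500000 nM, most likely reported only as a limit, within 500000 nM to 5000000 nM.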

Compound 4, half-maximal inhibitory concentration: 170000 nM
Compound 4: the middle estimate sits 8.8-fold (0.95 log units) above what was measured; the measured number lies below the stated range.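

In this assay, methoxy in place of methyl on an aromatic carbon gives a 1.3-fold lower number from compound 3 to compound 4 (0.13 log units; within the scatter) on the core of compound 3, so the change does not carry over in size from the core of compound 1. The two steps differ: the same change on two cores in this assay, an at least 6.2-fold higher number (0.79 log units; beyond the scatter) from compound 1 to compound 2 and a 1.3-fold lower number (0.13 log units; within the scatter) from compound 3 to compound 4, at least 8.3-fold (0.92 log units) apart, beyond the scatter of two such steps. This shows that, across these two pairs, the step seen on one core cannot be assumed on the other, but it does not show what sets the cores apart, and the earlier step has no exact size since it ends at a limit: the limit of > 500000 nM in this assay, at which 1 of the 4 values shown sits.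

The compounds shown leave open how an amine or a carboxylic acid at the same aromatic carbon would behave on either core. On these data alone, whether a third core would follow compound 1 or compound 3 also stays open.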